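Swapping the amide aryl group: clearance expected for compound 4

The compounds below may be only part of what the source reports. "The series", "measured", "known", "first", "only" and "open" are said of these compounds alone.

Compound 1 `CN1C[C@H](C(=O)Nc2ccc(C3CC3)cc2)[C@@H](c2ccc(/C=C/C(=O)Nc3ccccc3N)cc2)C1`: 12 mL/min/kg
Compound 2 `CN1C[C@H](C(=O)Nc2ccc(C(F)(F)F)cc2)[C@@H](c2ccc(/C=C/C(=O)Nc3ccccc3N)cc2)C1`: 6 mL/min/kg
Compound 3 `COc1cccc(NC(=O)[C@H]2CN(C)C[C@@H]2c2ccc(/C=C/C(=O)Nc3ccccc3N)cc2)c1`: 14 mL/min/kg

In an in vitro ADME assay on microsomes from liver (Homo sapiens) for pharmacokinetics, read by LC-MS, with a stated time of 10 min, tested at 1 uM (on this read-out higher numbers stand for fast clearance and lower numbers for slow clearance), compound 3 gives 14 mL/min/kg, the highest of the three numbers. Its nearest neighbour is compound 1, the step of a 1.2-fold higher number from compound 1 to compound 3 (0.07 log units; within the scatter) lying within the scatter, while the gap to compound 2, a 2.3-fold higher number from compound 2 to compound 3 (0.37 log units; beyond the scatter), is a modest one beyond the scatter.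

Compound 4 `CN1C[C@H](C(=O)Nc2ccc(Cl)cc2F)[C@@H](c2ccc(/C=C/C(=O)Nc3ccccc3N)cc2)C1` differs from compound 3 in one place: 4-chloro-2-fluorophenyl in place of 3-methoxyphenyl on an amide-type nitrogen. For the measured compounds named here, two measured steps bear on this kind of change, since both alter the aryl group on the same amide-type nitrogen. From compound 1 to compound 3 the number moved by a 1.2-fold higher number from compound 1 to compound 3 (0.07 log units; within the scatter), and from compound 2 to compound 3 by a 2.3-fold higher number from compound 2 to compound 3 (0.37 log units; beyond the scatter). Neither step is large, and the only one beyond the scatter runs from a halogenated aryl toward 3-methoxyphenyl. Going by the values given here, no compound carrying 4-chloro-2-fluorophenyl has been measured, so the direction rests on analogy alone.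

Compound 4 is therefore expected to show a step of a 1.6-fold lower number from compound 3 to compound 4 (0.19 log units; within the scatter) in this assay, a small move toward slower clearance. The estimated value for compound 4 is 9 mL/min/kg, with a range from 5 mL/min/kg to 18 mL/min/kg.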

Compound 4, clearance: 11 mL/min/kg
The estimate for compound 4 lay 1.2-fold (0.09 log units) below the measured number; the measured number falls inside the stated range.
By their numbers in this assay, from the lowest: compounds 2, 4, 1 and 3 (each within the scatter of the next, the first and the last beyond it).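

In this assay, the 4-chloro-2-fluorophenyl group on the amide-type nitrogen stays within the scatter of all three earlier aryl groups: a 1.3-fold lower number from compound 3 to compound 4 (0.10 log units; within the scatter), a 1.1-fold lower number from compound 1 to compound 4 (0.04 log units; within the scatter) and a 1.8-fold higher number from compound 2 to compound 4 (0.26 log units; within the scatter). The earlier compounds held one step beyond the scatter, a 2.3-fold higher number from compound 2 to compound 3 (0.37 log units; beyond the scatter), and compound 4 cannot be separated from either end of that modest gap, so the four aryl groups shown at this position span no wider a range than that single step. Nothing at hand accounts for how closely these aryl groups read in this assay.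

As far as these compounds go, all four compounds carry a substituted phenyl on this nitrogen, so it remains open whether a pyridine ring, a plain phenyl or a saturated cyclohexyl group there would give clearance in the same range. From the compounds shown here alone, the chlorine and the fluorine also appear only together, which leaves the share of each in the number for compound 4 unknown, and an amine or a carboxylic acid on the aryl ring remains an equally open case.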